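The source may hold more compounds than are shown below. What is called first, only, known or untested is meant among the compounds shown, and "the series" means these compounds.

Measured in a functional assay for agonist activity at G protein-coupled receptor 88 (Homo sapiens), read by HTRF and cAMP accumulation; on this read-out lower numbers stand for an effect already at smaller amounts and higher numbers for an effect only at larger amounts of compound:
Compound 1, `CC[C@H](C)[C@H](N)CN(C(=O)[C@@H]1C[C@H]1c1ccc(Cl)cc1)c1ccc(-c2ccccc2)cc1`, gives 4300 nM.
For compound 2, `CC[C@H](C)[C@H](N)CN(C(=O)[C@@H]1C[C@H]1c1ccc(C#N)cc1)c1ccc(-c2ccccc2)cc1`, only a limit of the assay is recorded, > 25000 nM, as noted in the limit of > 25000 nM in this assay, at which 1 of the 3 values shown sits.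
Compound 3, `CC[C@H](C)[C@H](N)CN(C(=O)[C@@H]1C[C@H]1c1cccc(C#N)c1)c1ccc(-c2ccccc2)cc1`, gives 1600 nM.

Compound 3 stands lowest of the two numbers; its nearest neighbour is compound 1, through a 2.7-fold lower number from compound 1 to compound 3 (0.43 log units; beyond the scatter). Compound 4, `CC[C@H](C)[C@H](N)CN(C(=O)[C@@H]1C[C@H]1c1c(F)cccc1F)c1ccc(-c2ccccc2)cc1`, differs from compound 3 by 2,6-difluorophenyl in place of 3-cyanophenyl on a saturated ring carbon. Going by the values given here, no measured step replaces the nitrile by fluorines, but an at least 15-fold lower number from compound 2 to compound 3 (1.19 log units; beyond the scatter) shows that where the nitrile sits on this phenyl ring matters greatly, and an at least 5.8-fold higher number from compound 1 to compound 2 (0.76 log units; beyond the scatter) shows that exchanging a halogen for the nitrile at one position matters too. Since compound 1, carrying a halogen, shows 4300 nM, a modest rise is expected for the step of a 2.5-fold higher number from compound 3 to compound 4 (0.40 log units; beyond the scatter). Compound 4 is therefore expected near 4000 nM, within 1000 nM to 15000 nM.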

Compound 4, half-maximal effective concentration: 11000 nM
Compound 4: middle estimate off by 2.8-fold (0.44 log units), on the low side; measured number inside the range.
By their numbers in this assay, from the lowest: compound 3; then compound 1; then compound 4. At a limit, above all of these: compound 2.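

In this assay, 2,6-difluorophenyl on this saturated ring carbon falls short of 3-cyanophenyl, with a 6.9-fold higher number from compound 3 to compound 4 (0.84 log units; beyond the scatter), and of 4-chlorophenyl, with a 2.6-fold higher number from compound 1 to compound 4 (0.41 log units; beyond the scatter). It still reads lower than 4-cyanophenyl, with an at least 2.2-fold lower number from compound 2 to compound 4 (0.35 log units; beyond the scatter), so a ring without a nitrile can sit between the two cyanophenyl isomers. That last step is bounded on one side only, and compound 2 stands at a limit: the limit of > 25000 nM in this assay, at which 1 of the 4 values shown sits.

Open, from the compounds shown here alone, is whether a single fluorine on the phenyl ring reads like two. Also open, going by these compounds, is whether a methoxy group or an amine there would approach compound 3.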